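Thiazole for Pyridine on the Cyclopropane Amide

A few compounds are considered here, and "the series" means these few. Any claim that something is new, unique, unknown or untested is made for them only; others in the source may bear on it.

Compound 1 `CC[C@H](C)[C@H](N)CN(C(=O)[C@@H]1C[C@H]1C1CCCCC1)c1ccc(-c2ccccc2)cc1`: in a functional assay for agonist activity at G protein-coupled receptor 88 (Homo sapiens), read by HTRF and cAMP accumulation (a higher number here means that more compound is needed for the effect, a lower number that less compound is needed), compound 1 gives > 25000 nM, which is a limit of the assay and not a number.
Compound 2 `CC[C@H](C)[C@H](N)CN(C(=O)[C@@H]1C[C@H]1c1ccccn1)c1ccc(-c2ccccc2)cc1`: in this assay compound 2 gives 130 nM.

Compound 2 holds the only number shown; the other value is a limit, (the limit of > 25000 nM in this assay, at which 1 of the 2 values shown sits). Among the measured compounds shown here, the single measured step, an at least 190-fold lower number from compound 1 to compound 2 (2.28 log units; beyond the scatter), is large and beyond the scatter. Compound 3 `CC[C@H](C)[C@H](N)CN(C(=O)[C@@H]1C[C@H]1c1nccs1)c1ccc(-c2ccccc2)cc1` differs from compound 2 by 1,3-thiazol-2-yl in place of pyridin-2-yl on a saturated ring carbon. For the measured compounds named here, the step from compound 1 to compound 2 bears on this only loosely: it shows that the group on this saturated ring carbon can move the number a great deal, yet it sets a saturated ring against an aromatic one, whereas here one aromatic heterocycle replaces another, and no step of that kind has been measured. A modest change in this assay, in either direction, is therefore expected. Compound 3 is estimated at 200 nM, within 50 nM to 800 nM, which is expected to mean a step of a 1.5-fold higher number from compound 2 to compound 3 (0.19 log units; within the scatter) close to the scatter.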

Compound 3, half-maximal effective concentration: 210 nM
For compound 3 the middle estimate is 1.1-fold (0.02 log units) below the measured one, within the range that was stated.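

In this assay, the only exchange shown of one aromatic heterocycle for another on this saturated ring carbon of the three-membered ring gives a 1.6-fold higher number from compound 2 to compound 3 (0.21 log units; within the scatter), so pyridin-2-yl and 1,3-thiazol-2-yl are not told apart here, although ring size and hetero atoms differ. The large step away from cyclohexyl recurs with the five-membered aromatic ring, an at least 110-fold lower number from compound 1 to compound 3 (2.07 log units; beyond the scatter), and so is not tied to pyridin-2-yl alone. For compound 1 the value is a limit of the assay and not a number, so this step gives only a bound: the limit of > 25000 nM in this assay, at which 1 of the 3 values shown sits.

Going by these compounds, what stays open is whether the ring nitrogen matters at all, which a plain phenyl in this place could address. On these data alone, it also remains open whether a non-aromatic ring carrying nitrogen, such as piperidinyl, would behave like cyclohexyl or like the two aromatic rings.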